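This account rests on a few compounds, and the source may have more. Where it says the series, first, only, none or still open, it means among the compounds named here.

Compound 1, `O=Cc1ccc(-c2cn3ccnc3c(-c3ccc4ncn(C5CCCCC5)c4c3)n2)cc1`: 23% in a functional assay on M14 cells (Homo sapiens) for inhibition, read by sulforhodamine B assay, with a stated time of 48 h, tested at 10 uM; on this read-out lower numbers stand for less inhibition and higher numbers for more inhibition at the one concentration tested (going by the name of the read-out)
Compound 2, `Clc1ccc(-c2cn3ccnc3c(-c3ccc4ncn(C5CCCCC5)c4c3)n2)cc1`: 10% in this assay
Compound 3, `COc1ccccc1-c1cn2ccnc2c(-c2ccc3ncn(C4CCCCC4)c3c2)n1`: 1.12% in this assay

Compound 3 stands lowest of the three numbers in this assay. Its nearest neighbour is compound 2, which lies a number 8.9 percentage points lower from compound 2 to compound 3 (within the scatter) apart in the other direction, a gap within the scatter, so the two cannot be ordered. Compound 1 is furthest away: the step of a number 21.9 percentage points lower from compound 1 to compound 3 (beyond the scatter) lies beyond the scatter, as does a number 13 percentage points lower from compound 1 to compound 2 (beyond the scatter).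

Compound 4, `Fc1ccccc1-c1cn2ccnc2c(-c2ccc3ncn(C4CCCCC4)c3c2)n1`, differs from compound 3 in one place: fluoro in place of methoxy on an aromatic carbon. Among the compounds with values here, none of the measured steps repeats this exchange. Within the data shown here, the nearest comparison is chloro in place of formyl, where a number 13 percentage points lower from compound 1 to compound 2 (beyond the scatter) was modest; a halogen replacing a methoxy has no measured counterpart here. With compound 3 already at the bottom of a narrow range, no step beyond the scatter is expected in this assay in either direction. Compound 4 is therefore estimated at 5%, with a range from 0% to 18%. This amounts to an expected step of a number 3.9 percentage points higher from compound 3 to compound 4 (within the scatter), within the scatter.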

Compound 4, a percentage reported as inhibition, at one concentration (the size of the read-out at that concentration, not a potency): 2.92%
Estimate against measurement, compound 4: 2.1 percentage points above, and the stated range covers the measured number.
By their numbers in this assay, from the lowest: compounds 3, 4 and 2 (each within the scatter of the next); then compound 1.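

In this assay, fluoro in place of methoxy on an aromatic carbon ortho to a large group gives a number 1.8 percentage points higher from compound 3 to compound 4 (within the scatter) and so leaves the two compounds unordered, which shows that this single exchange on the ring makes no readable difference. The 2-fluorophenyl compound also cannot be ordered against the 4-chlorophenyl compound, with a number 7.1 percentage points lower from compound 2 to compound 4 (within the scatter) and the 4-formylphenyl compound remains apart, with a number 20.1 percentage points lower from compound 1 to compound 4 (beyond the scatter) as the step to this new compound. Nothing available here bears on the reason for these numbers.

On these data alone, all of these numbers come from one cell line at one concentration, so how the compounds would rank at other concentrations stays open. As far as these compounds go, whether an amine or a carboxylic acid at this same place would lift the number out of this low range also stays open.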